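A few compounds are considered here, and "the series" means these few. Any claim that something is new, unique, unknown or untested is made for them only; others in the source may bear on it.

Working notes on the series, read in a functional assay on cells (Cancer cell lines, Homo sapiens) for inhibition; a higher number here means a weaker inhibitor of growth, a lower number a stronger inhibitor of growth. Compound 1 `Cc1cc(-c2nc3sc(C)cn3c2/C=N/NC(=N)N)c(C)s1` gives 12000 nM, compound 2 `Cc1cn2c(/C=N/NC(=N)N)c(-c3ccsc3)nc2s1` gives 11000 nM, and compound 3 `N=C(N)N/N=C/c1c(-c2cc(Cl)sc2Cl)nc2n1CCS2` gives 10500 nM. These three values lie within the scatter of each other, so compound 2 cannot be told apart from the other two.

Compound 4 `N=C(N)N/N=C/c1c(-c2ccsc2)nc2sccn12` differs from compound 2 by hydrogen in place of methyl on an aromatic carbon, next to the ring sulfur.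

For the measured compounds named here, only one measured step bears on this change, and only indirectly. Thiophen-3-yl in place of 2,5-dimethylthiophen-3-yl gives a 1.1-fold lower number from compound 1 to compound 2 (0.04 log units; within the scatter), so that loss of methyl groups left the value within the scatter. Going by the values given here, that step lies elsewhere in the molecule, and no measured step covers this methyl itself, so the support is limited.

The expected step is no change at the digits printed from compound 2 to compound 4 (within the scatter), with no change beyond the scatter anticipated in either direction. For compound 4 the estimated value is 11000 nM, with an expected range of 5000 nM to 22000 nM.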

Compound 4, concentration for 50% growth inhibition: 15500 nM
For compound 4 the middle estimate is 1.4-fold (0.15 log units) below the measured one; low and high end bracket the measured number.
By their numbers in this assay, from the lowest: compounds 3, 2, 1 and 4 (each within the scatter of the next).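

Hydrogen in place of methyl on an aromatic carbon, next to the ring sulfur, gives a 1.4-fold higher number from compound 2 to compound 4 (0.15 log units; within the scatter) in this assay and provides the first measured step at this position. The earlier step removed methyl groups elsewhere in the molecule, whereas this one shows directly that the methyl here can be exchanged for hydrogen without a change beyond the scatter. No measured evidence bears on the size of this step or links it to any property of the methyl group.

On these data alone, whether an ethyl group, an aminomethyl group or a carboxylic acid at this carbon would move the number beyond the scatter stays open. The step between methyl and hydrogen lies within the scatter. The compounds shown leave undecided whether this position has any influence on growth inhibition.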